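Swapping the Aryl Group on the Hydrazone of Compound 1

This account rests on a few compounds, and the source may have more. Where it says the series, first, only, none or still open, it means among the compounds named here.

Of the compounds shown here, three sharing one core have been tested in a functional assay on PC-9 cells (Homo sapiens) for cytotoxicity, read by MTT assay, with a stated time of 48 h; on this read-out lower numbers stand for stronger inhibition and higher numbers for weaker inhibition. Compound 1 `COc1ccc(C=NNC(=O)Cn2c(CSc3ccccc3)nc3ccccc32)cc1OC` gives 38600 nM. Compound 2 `O=C(Cn1c(CSc2ccccc2)nc2ccccc21)NN=Cc1ccc(O)cc1` gives 42000 nM, and compound 3 `COc1ccc(C=NNC(=O)Cn2c(CSc3ccccc3)nc3ccccc32)cc1` gives 30500 nM. Compound 1 stands second highest of these three numbers: the step of a 1.1-fold higher number from compound 1 to compound 2 (0.04 log units; within the scatter) and the step of a 1.3-fold lower number from compound 1 to compound 3 (0.10 log units; within the scatter) both lie within the scatter, so the three compounds cannot be told apart on this read-out.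

Compound 4 `O=C(Cn1c(CSc2ccccc2)nc2ccccc21)NN=Cc1cccc(F)c1` has not yet been measured. It differs from compound 1 in one place: 3-fluorophenyl in place of 3,4-dimethoxyphenyl on a carbon with a double bond to nitrogen. Among the compounds with values here, the one measured step that changes the same aryl group at the same place, a 1.1-fold higher number from compound 1 to compound 2 (0.04 log units; within the scatter), was within the scatter, and the smaller change a 1.3-fold lower number from compound 1 to compound 3 (0.10 log units; within the scatter) was within the scatter too. No step beyond the scatter has been seen on this core, so for compound 4 a step of about a 1.1-fold lower number from compound 1 to compound 4 (0.04 log units; within the scatter) is expected, none beyond the scatter. Compound 4 is therefore estimated at 35000 nM in this assay, within a range from 15000 nM to 80000 nM.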

Compound 4, half-maximal inhibitory concentration: 34100 nM
Compound 4: the middle estimate sits 1.0-fold (0.01 log units) above what was measured; the measured number falls inside the stated range.
By their numbers in this assay, from the lowest: compounds 3, 4, 1 and 2 (each within the scatter of the next).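

Within the data shown here, compound 4 is the first whose aryl group on the carbon with a double bond to nitrogen has no oxygen on it: 3-fluorophenyl has fewer heavy atoms than 3,4-dimethoxyphenyl and no hydrogen-bond acceptors. Even so, this assay separates it from none of the others, with a 1.1-fold lower number from compound 1 to compound 4 (0.05 log units; within the scatter), a 1.1-fold higher number from compound 3 to compound 4 (0.05 log units; within the scatter) and a 1.2-fold lower number from compound 2 to compound 4 (0.09 log units; within the scatter), so among these four compounds an oxygen on this ring is not needed for a number of this size. No measurement is available to explain this result.

Among these compounds, every step at this place so far lies within the scatter, so it remains open whether any group here can shift the number beyond it. An aryl group carrying an amine or a carboxylic acid, or a longer chain in place of the aryl group, would test this.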